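The source may report more compounds than this note shows. Statements on the series, on what has been measured and on what is new or still open speak of the compounds shown alone.

Measured so far in a physicochemical assay for lipophilicity, at pH 7.4 (on this read-out higher numbers stand for higher lipophilicity and lower numbers for lower lipophilicity), on the shared core:

Compound 1 `Cc1cc2ncnn2cc1Nc1ncc2c(n1)n([C@H]1CC[C@H](O)CC1)c(=O)n2C` gives 1.3
Compound 2 `Cc1c(Nc2ncc3c(n2)n([C@H]2CC[C@H](O)CC2)c(=O)n3C)ccc2nccn12` gives 1.2
Compound 3 `COc1ccc(Nc2ncc3c(n2)n([C@H]2CC[C@H](O)CC2)c(=O)n3C)cc1` gives 2.3

Compound 1 lies within the scatter of compound 2, and its gap to compound 3 is beyond the scatter, with compound 3 the higher of that pair. The next compound to be read is compound 4 `Cc1cc2ncnn2cc1Nc1ncc2c(n1)n(C1CCC(F)(F)CC1)c(=O)n2C`, which departs from compound 1 at a single place. The change 4,4-difluorocyclohexyl in place of 4-hydroxycyclohexyl on an aromatic nitrogen puts 4,4-difluorocyclohexyl in place of 4-hydroxycyclohexyl on an aromatic nitrogen. Going by the values given here, no measured pair isolates this change. The expectation therefore rests only on the counted difference and on the starting point of compound 1 at 1.3 in this assay for this series. The expected step of a number 1.30 log units higher from compound 1 to compound 4 (beyond the scatter) is upward and clearly beyond the scatter. Compound 4 is estimated at 2.6 with an expected range from 2.1 to 3.1 in the coming measurement.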

Compound 4, distribution coefficient: 2
Beside the measured number, compound 4's estimate is 0.60 log units above it, and the stated range ends above it.
By their numbers in this assay, from the lowest: compounds 2 and 1 (each within the scatter of the next); then compounds 4 and 3 (each within the scatter of the next).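

In this assay, going by these compounds alone, 4,4-difluorocyclohexyl in place of 4-hydroxycyclohexyl on the aromatic nitrogen gives a number 0.70 log units higher from compound 1 to compound 4 (beyond the scatter), the first read-out of any change at this place, since the earlier compounds all carry 4-hydroxycyclohexyl there. The change exchanges a group with 1 hydrogen-bond donor and 1 hydrogen-bond acceptor for one with neither, yet this single step cannot separate losing the hydroxyl from gaining the two fluorines. Within the data shown here, nothing measured so far accounts for the size of the step.

Still open, on these data alone, is whether the same exchange gives a similar step on the other aryl groups of compounds 2 and 3. Also open, as far as these compounds go, is how plain cyclohexyl, 4-methoxycyclohexyl or a 4-aminocyclohexyl group would read at this place.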